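Ester for sulfone on the double-bonded chain carbon

The source may hold more compounds than are shown below. What is called first, only, known or untested is meant among the compounds shown, and "the series" means these compounds.

In a functional assay on MT4 cells (Homo sapiens) for antiproliferative activity, read by MTT assay, with a stated time of 96 h (on this read-out higher numbers stand for an effect only at larger amounts of compound and lower numbers for an effect already at smaller amounts), compound 3 `O=C(/C(=C\c1c(-c2ccccc2)[nH]c2ccccc12)S(=O)(=O)c1ccccc1)c1ccccc1` gives 3000 nM, the higher of the two numbers in hand. Compound 2 `CC(=O)/C(=C\c1c(-c2ccccc2)[nH]c2ccccc12)S(=O)(=O)c1ccccc1` gives 400 nM in this assay. Among the measured compounds shown here, the one measured step, a 7.5-fold higher number from compound 2 to compound 3 (0.88 log units; beyond the scatter), lies between these two. Compound 1 `CCOC(=O)/C(=C/c1c[nH]c2ccccc12)C(=O)c1ccccc1` yields only a limit in this assay, > 100000 nM, and not a number. Compound 4 `CCOC(=O)/C(=C/c1c(-c2ccccc2)[nH]c2ccccc12)C(=O)c1ccccc1` is not yet measured. From compound 3 the change is ethoxycarbonyl in place of phenylsulfonyl on a double-bonded chain carbon bound to a carbonyl carbon and a double-bonded chain carbon. For the measured compounds named here, no measured step bears directly on this swap: the single step in hand alters the group on the carbonyl carbon, not the group on the double-bonded chain carbon. Compound 1 carries the same pairing of ethoxycarbonyl and benzoyl as compound 4 and sits at the limit (the limit of > 100000 nM in this assay, at which 1 of the 3 values shown sits), so the expectation for compound 4 is a higher number beyond the scatter, an estimated 10-fold higher number from compound 3 to compound 4 (1.00 log units; beyond the scatter). Compound 4 is therefore expected at 30000 nM, within 5000 nM to 150000 nM, with a real chance that this assay again returns only a limit.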

Compound 4, half-maximal effective concentration: 7000 nM
Estimate against measurement, compound 4: 4.3-fold (0.63 log units) above, and the stated range covers the measured number.
By their numbers in this assay, from the lowest: compound 2; then compound 3; then compound 4. At a limit, above all of these: compound 1.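

With a 2.3-fold higher number from compound 3 to compound 4 (0.37 log units; beyond the scatter), ethoxycarbonyl in place of phenylsulfonyl on this double-bonded chain carbon still leaves a measured number in this assay, so the pairing of ethoxycarbonyl and benzoyl does not by itself put a compound at the limit. Phenyl in place of hydrogen on an aromatic carbon gives an at least 14-fold lower number from compound 1 to compound 4 (1.15 log units; beyond the scatter), the first step shown for that change, and in this pair it separates a measured number from a limit. Compound 1 remains a limit and not a number: the limit of > 100000 nM in this assay, at which 1 of the 4 values shown sits.

Going by these compounds, whether the swap from phenylsulfonyl to ethoxycarbonyl runs the same way with methyl on the carbonyl carbon, as in compound 2, stays open. Also open, on these data alone, is how a carboxylic acid or a primary amide would read on the double-bonded chain carbon, or a methyl group in place of the phenyl on the aromatic carbon.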